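Swapping a Fluorophenyl Ring for a Thiazole Ring

This account rests on a few compounds, and the source may have more. Where it says the series, first, only, none or still open, it means among the compounds named here.

The measured compounds and their values in a functional assay on A549 cells (Homo sapiens) for inhibition, read by MTT assay, with a stated time of 48 h; a lower number here means a stronger inhibitor, a higher number a weaker inhibitor:
compound 1 `Nc1n[nH]c2cccc(-c3cccc(NC(=O)Nc4cccc(Cl)c4)c3)c12` gives 1720 nM
compound 2 `Nc1n[nH]c2cccc(-c3cccc(NC(=O)Nc4ccc(Cl)c(C(F)(F)F)c4)c3)c12` gives 3410 nM
compound 3 `Nc1n[nH]c2cccc(-c3cccc(NC(=O)Nc4cccc(F)c4)c3)c12` gives 1360 nM

All three share one core and differ only in the ring at the far end. Compound 3 has the lowest number of the three, but its gap to compound 1 is small: a 1.3-fold lower number from compound 1 to compound 3 (0.10 log units; within the scatter), a change that stays within the scatter, so the two cannot be ranked. Compound 2 sits clearly higher than compound 3, beyond the scatter.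

Compound 4 `Nc1n[nH]c2cccc(-c3cccc(NC(=O)Nc4nccs4)c3)c12` has not yet been measured. Relative to compound 3 it carries 1,3-thiazol-2-yl in place of 3-fluorophenyl on an amide-type nitrogen. Among the compounds with values here, none of the measured steps makes a change of this kind; the one step on record swaps a halogen for another halogen on the same ring and barely moves the number, and compound 2 only shows that adding a trifluoromethyl to that ring raises it. Within the data shown here, a full ring exchange therefore has no direct precedent here, and the expectation must be loose. A modest rise, a 1.8-fold higher number from compound 3 to compound 4 (0.26 log units; within the scatter), is expected, with wide uncertainty. Compound 4 is estimated at 2500 nM, in a range from 800 nM to 8000 nM.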

Compound 4, half-maximal inhibitory concentration: > 500000 nM
Compound 4 ended at the assay's limit; the forecaster's own chance of this, stated with the estimate: 10%; middle value at least 200-fold (2.30 log units) away from the limit.
By their numbers in this assay, from the lowest: compounds 3, 1 and 2 (each within the scatter of the next, the first and the last beyond it). At a limit, above all of these: compound 4.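

Changing only the halogen or adding a trifluoromethyl on the phenyl ring leaves compounds 1, 2 and 3 within a narrow band, but exchanging the ring itself on this amide-type nitrogen has a far larger effect: an at least 360-fold higher number from compound 3 to compound 4 (2.56 log units; beyond the scatter). The comparison with the chloro analogue points the same way, with an at least 290-fold higher number from compound 1 to compound 4 (2.46 log units; beyond the scatter), so the large change does not depend on which of these two halogen-bearing phenyl rings serves as the reference. At this position, then, the identity of the ring matters far more than the substituent changes seen so far, although the true size of the change remains unknown, since compound 4 gives only a limit of the assay rather than a number: the limit of > 500000 nM in this assay, at which 1 of the 4 values shown sits.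

The compounds shown cannot say whether the loss goes with the five-membered ring or with the nitrogen and sulfur atoms it carries, and a pyridine ring or a thiophene ring at this place would help separate the two. An unsubstituted phenyl ring would also show how much the halogen on the ring contributes to the values of compound 1 and compound 3.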